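This account rests on a few compounds, and the source may have more. Where it says the series, first, only, none or still open, it means among the compounds named here.

Working notes on the series in a functional assay on Malme-3M cells (Homo sapiens) for antiproliferative activity; a lower number here means a stronger inhibitor of growth, a higher number a weaker inhibitor of growth. Compound 1 `CC(=O)Nc1ccc(S(=O)(=O)NNC(=O)c2cccnc2Nc2ccc(Cl)cc2)cc1` is the reference point. In this assay compound 1 gives only a limit, < 100000 nM, so its standing is a bound rather than a number; this is the limit of < 100000 nM in this assay, at which 1 of the 2 values shown sits. Compound 2 `O=C(NNS(=O)(=O)c1ccc(F)cc1)c1cccnc1Nc1ccc(Cl)cc1Cl` differs from compound 1 in more than one place, and in this assay compound 2 gives 34700 nM, a number rather than a limit. Compound 3 `O=C(NNS(=O)(=O)c1ccc(Cl)cc1Cl)c1cccnc1Nc1ccc(Cl)cc1` has not yet been measured. It differs from compound 1 in one place: 2,4-dichlorophenyl in place of 4-acetamidophenyl on a sulfonyl sulfur. Going by the values given here, no measured step matches this change, so any expectation rests on the bound for compound 1 and the number for compound 2 alone. The step that the limit leaves unreadable from compound 1 to compound 3 is expected to run from the limit toward stronger inhibition of growth, though its size cannot be read off a limit. For compound 3 the estimate is 40000 nM, within 10000 nM to 100000 nM.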

Compound 3, concentration for 50% growth inhibition: 34700 nM
Compound 3: the middle estimate sits 1.2-fold (0.06 log units) above what was measured; the range from low to high includes it.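

No step can be read from compound 1 to compound 3, because compound 1 stands only as a limit in this assay: the limit of < 100000 nM in this assay, at which 1 of the 3 values shown sits.

The compounds shown leave open how large an effect 2,4-dichlorophenyl in place of 4-acetamidophenyl on a sulfonyl sulfur has on growth inhibition.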